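A few compounds are considered here, and "the series" means these few. Any claim that something is new, unique, unknown or untested is made for them only; others in the source may bear on it.

In a functional assay on MCF7 cells (Homo sapiens) for inhibition, read by MTT assay, with a stated time of 72 h (on this read-out lower numbers stand for stronger inhibition and higher numbers for weaker inhibition), compound 1 `COc1ccc(-c2nnc(SCCCN3CCN(c4nc5ccccc5o4)CC3)o2)cc1` gives 52800 nM. Compound 2 `O=[N+]([O-])c1ccc(-c2nnc(SCCCN3CCN(c4nc5ccccc5o4)CC3)o2)cc1`, with nitro in place of methoxy on an aromatic carbon, gives 90100 nM. Within the data shown here, these two numbers lie within the scatter of each other, so they cannot be ranked, and compound 2 stands level with the only other compound measured so far.

Compound 3 `Cc1ccc(-c2nnc(SCCCN3CCN(c4nc5ccccc5o4)CC3)o2)cc1` has not yet been measured. It keeps the rest of compound 2 and alters a single group: methyl in place of nitro on an aromatic carbon. In words, this is methyl in place of nitro on an aromatic carbon, the change from 4-nitrophenyl to 4-methylphenyl.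

Among the measured compounds shown here, only one measured step bears on this change. That step, a 1.7-fold higher number from compound 1 to compound 2 (0.23 log units; within the scatter), exchanged one group for another at the same aromatic carbon. Methyl itself has not been tested, so this is only a rough guide, but no step beyond the scatter is expected in this assay, in either direction. The expected outcome is a 1.4-fold lower number from compound 2 to compound 3 (0.14 log units; within the scatter). Compound 3 is estimated at 65000 nM, with an expected range of 28000 nM to 140000 nM.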

Compound 3, half-maximal inhibitory concentration: 60400 nM
For compound 3 the middle estimate is 1.1-fold (0.03 log units) above the measured one, within the range that was stated.
By their numbers in this assay, from the lowest: compounds 1, 3 and 2 (each within the scatter of the next).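

In this assay, replacing nitro with methyl on the aromatic carbon para to a large group gives a 1.5-fold lower number from compound 2 to compound 3 (0.17 log units; within the scatter) and replacing methoxy with methyl gives a 1.1-fold higher number from compound 1 to compound 3 (0.06 log units; within the scatter). This position has now carried three different groups, and all three compounds stand level, so the earlier pair's lack of a readable difference now extends to a third group, one that differs from nitro in size and hydrogen-bonding count: nitro has 3 heavy atoms and 2 hydrogen-bond acceptors, whereas methyl has 1 heavy atom and 0 hydrogen-bond acceptors. No measurement of any property of these groups accompanies the result, so the data offer no explanation for why the three compounds stand level.

As far as these compounds go, whether an amine, a carboxylic acid or a chlorine atom at this carbon would produce a step beyond the scatter remains open, as does the effect of a longer chain such as propyl. The rest of the structure is the same in all three compounds, so these results also leave open how changes in the shared core would affect the number.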